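Restoring the Amine Hydrogen on the Shared Core

A few compounds are considered here, and "the series" means these few. Any claim that something is new, unique, unknown or untested is made for them only; others in the source may bear on it.

Of the compounds shown here, three built on one shared core have been tested in an assay on CHO cells for displacement of a labelled ligand from adenosine receptor A3 (Homo sapiens); a higher number here means a weaker inhibitor, a lower number a stronger inhibitor. Compound 1 `CCOC(=O)c1cnc(NC2CCCC2)n2nc(-c3ccco3)nc12` gives 35 nM, and compound 2 `CCOC(=O)c1cnc(NCc2ccc(F)cc2)n2nc(-c3ccco3)nc12` gives 46.3 nM; the step between them, a 1.3-fold higher number from compound 1 to compound 2 (0.12 log units; within the scatter), is small. Compound 3 `CCOC(=O)c1cnc(N2CCCCC2)n2nc(-c3ccco3)nc12` gives 1770 nM, the highest of the three numbers, making it the weakest inhibitor of the set, with a 51-fold higher number from compound 1 to compound 3 (1.70 log units; beyond the scatter) and a 38-fold higher number from compound 2 to compound 3 (1.58 log units; beyond the scatter). Compound 4 `CCOC(=O)c1cnc(NCCOC)n2nc(-c3ccco3)nc12` has not yet been measured. It differs from compound 3 by (2-methoxyethyl)amino in place of piperidin-1-yl on an aromatic carbon. Compounds 1 and 2, like compound 4, carry a secondary amine, whereas compound 3 carries a tertiary one, and both measured steps into compound 3 were large rises in the number. Going by the values given here, the step out of compound 3 is therefore expected to be a large fall, an 18-fold lower number from compound 3 to compound 4 (1.25 log units; beyond the scatter), though the spread is wide since no measured compound carries this exact chain. For compound 4 the estimate in this assay is 100 nM, with a range from 30 nM to 400 nM.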

Compound 4, inhibition constant: 105 nM
The estimate for compound 4 lay 1.1-fold (0.02 log units) below the measured number; measured number inside the range.
By their numbers in this assay, from the lowest: compounds 1 and 2 (each within the scatter of the next); then compound 4; then compound 3.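

In this assay, the open (2-methoxyethyl)amino chain brings a 17-fold lower number from compound 3 to compound 4 (1.23 log units; beyond the scatter) and so gives a third secondary amine with a far lower number than the piperidin-1-yl compound, showing that neither a cyclopentyl ring nor a 4-fluorobenzyl group is required for that fall. The group on the nitrogen still matters, though, since the chain leaves a 2.3-fold higher number from compound 2 to compound 4 (0.36 log units; beyond the scatter) and also a 3.0-fold higher number from compound 1 to compound 4 (0.48 log units; beyond the scatter) as modest rises that lie beyond the scatter. No measured evidence here accounts for these differences.

The compounds shown leave open whether the amine hydrogen or the piperidin-1-yl ring itself drives the large gap, a question that dimethylamino, a tertiary amine with no ring, would help to separate. Also open, as far as these compounds go, is what the chain's oxygen contributes, which a plain butylamino chain would test.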